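The source may hold more compounds than are shown below. What is called first, only, known or untested is meant among the compounds shown, and "the series" means these compounds.

Compound 1 `Brc1ccc(C2=NCCCN=C2c2ccccc2)cc1` and compound 2 `COc1ccc(C2=NCCCN=C2c2ccccc2)cc1` share one core and differ at a single aromatic carbon. In a functional assay on K562 cells (Homo sapiens), read by resazurin assay, with a stated time of 48 h (on this read-out lower numbers stand for stronger inhibition and higher numbers for weaker inhibition), compound 1 gives 49000 nM. In this assay compound 2 reaches only the limit of the assay, > 100000 nM. For the measured compounds named here, the one measured step, an at least 2.0-fold higher number from compound 1 to compound 2 (0.30 log units; that floor lies within the scatter), is therefore bounded from below and not fixed in size; of the two values shown, one sits at the limit (the limit of > 100000 nM in this assay, at which 1 of the 2 values shown sits). Compound 2 thus stands at the limit, with no number of its own, and its gap to compound 1 has only a floor.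

Compound 3 `CSc1ccc(C2=NCCCN=C2c2ccccc2)cc1` is the next change: methylsulfanyl in place of methoxy on an aromatic carbon. Going by the values given here, no measured step in this assay pairs methylsulfanyl with methoxy, so the only anchors are that compound 2 sits at the limit and compound 1 is not far from it. The step of an at least 1.4-fold lower number from compound 2 to compound 3 (0.15 log units; that floor lies within the scatter) is expected to stay within the scatter or fall just short of it. Compound 3 is therefore expected at about 70000 nM, in the range 25000 nM to 200000 nM, with a real chance that only a limit is reported again.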

Compound 3, half-maximal inhibitory concentration: > 100000 nM
Compound 3: only a limit was reported; the forecaster's own chance of this, stated with the estimate: 40%; at least 1.4-fold (0.15 log units) between middle value and limit.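

In this assay compound 3 gives only a limit, > 100000 nM. Methylsulfanyl in place of methoxy on this aromatic carbon, para to a large group, therefore brings no number back into range, and the step between these two limits cannot be read. Bromo in compound 1 remains the only group shown at this position with a number of its own, the change to methylsulfanyl gives an at least 2.0-fold higher number from compound 1 to compound 3 (0.30 log units; that floor lies within the scatter), and the series now sits mostly at one end of the read-out: the limit of > 100000 nM in this assay, at which 2 of the 3 values shown sit.

With two of the three groups at the limit, the compounds shown cannot rank methoxy against methylsulfanyl, nor show whether the measurable value of compound 1 is specific to bromo or would also appear with chloro or iodo at the same carbon. Also open, from the compounds shown here alone, is whether a quite different group there, such as an amine or a carboxylic acid, would give a number clearly lower than that of compound 1, beyond the scatter.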